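The source may report more compounds than this note shows. Statements on the series, on what has been measured and on what is new or still open speak of the compounds shown alone.

Of the compounds shown here, three sharing one core have been measured in a functional assay (B cells) with Mus musculus as the target; a lower number here means that less compound is needed, a higher number that more compound is needed for the effect. Compound 1, `Nc1nc(O)c2c(n1)n(C1OC(CO)[C@@H](O)[C@H]1O)c(=O)n2C/C=C/c1ccccc1`, gives 103 uM, the highest of the three numbers, so it needs the most compound for the effect. Compound 2, `C=CCn1c(=S)n(C2OC(COCc3ccccc3)[C@H]3OC(C)(C)O[C@@H]23)c2nc(N)nc(O)c21`, gives 47 uM, and compound 3, `CCCn1c(=O)n(C2OC(COP(=O)(O)O)[C@@H](O)[C@H]2O)c2nc(N)nc(O)c21`, gives 15 uM; both gaps from compound 1 lie beyond the usual scatter. Compound 4, `[N-]=[N+]=NCC(O)Cn1c(=O)n(C2OC(CO)[C@@H](O)[C@H]2O)c2nc(N)nc(O)c21`, has not been measured in this assay. It differs from compound 1 in one place: 2-azido-1-hydroxyethyl in place of 2-phenylethenyl on a saturated chain carbon bound to an aromatic nitrogen. Among the compounds with values here, with no measured pair sharing this exact change, the expectation rests on the three values alone. For compound 4 a small step downward, or none beyond the scatter, is expected, written as a 1.7-fold lower number from compound 1 to compound 4 (0.23 log units; within the scatter). Compound 4 is therefore estimated at 60 uM, within 15 uM to 250 uM.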

Compound 4, concentration for half-maximal effect: 39 uM
Estimate against measurement, compound 4: 1.5-fold (0.19 log units) above; low and high end bracket the measured number.
By their numbers in this assay, from the lowest: compound 3; then compounds 4 and 2 (each within the scatter of the next); then compound 1.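

In this assay, the step to 2-azido-1-hydroxyethyl in place of 2-phenylethenyl gives a 2.6-fold lower number from compound 1 to compound 4 (0.42 log units; beyond the scatter) and shows that the effect at this position does not depend on the phenyl ring, since the compound without it needs less compound. The earlier compounds shown here could not show this, as none was a one-place change from another. Nothing measured here explains the shift. The compounds shown leave open whether the azide or the hydroxyl accounts for the lower number, and what an amine or a carboxylic acid on this chain would give.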